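Swapping the sulfonyl aryl group: an expectation for compound 4

The source may hold more compounds than are shown below. What is called first, only, known or untested is meant among the compounds shown, and "the series" means these compounds.

Of the compounds shown here, three sharing one core have been measured in an ADME assay on cells (Hepatocyte, Mus musculus) for cytotoxicity, read by MTT assay, with a stated time of 24 h; a higher number here means that more compound is tolerated, a lower number that less compound is tolerated. Compound 1 `O=S(=O)(c1ccccc1)n1c(-c2cn(-c3ccccc3)nc2-c2ccc(C(F)(F)F)cc2)nc2ccccc21` gives 186000 nM. Compound 2 `COc1ccc(S(=O)(=O)n2c(-c3cn(-c4ccccc4)nc3-c3ccc(C(F)(F)F)cc3)nc3ccccc32)cc1` gives 87400 nM. Compound 3 `Cc1ccc(C)c(S(=O)(=O)n2c(-c3cn(-c4ccccc4)nc3-c3ccc(C(F)(F)F)cc3)nc3ccccc32)c1` gives 132000 nM, the second highest of the three numbers; its nearest neighbour is compound 1 and its furthest is compound 2, both within the scatter of it. The step of a 2.1-fold lower number from compound 1 to compound 2 (0.33 log units; beyond the scatter) is the only one beyond the scatter, whereas a 1.4-fold lower number from compound 1 to compound 3 (0.15 log units; within the scatter) and a 1.5-fold higher number from compound 2 to compound 3 (0.18 log units; within the scatter) are not.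

Compound 4 `O=S(=O)(c1ccc(F)cc1)n1c(-c2cn(-c3ccccc3)nc2-c2ccc(C(F)(F)F)cc2)nc2ccccc21` differs from compound 3 by 4-fluorophenyl in place of 2,5-dimethylphenyl on a sulfonyl sulfur. Going by the values given here, the steps that bear on this change are the two other swaps on the sulfonyl sulfur, a 1.4-fold lower number from compound 1 to compound 3 (0.15 log units; within the scatter) and a 1.5-fold higher number from compound 2 to compound 3 (0.18 log units; within the scatter), both within the scatter, while the modest change a 2.1-fold lower number from compound 1 to compound 2 (0.33 log units; beyond the scatter) came from a methoxy on an aromatic carbon. Compound 4 is therefore expected to show no step beyond the scatter, a 1.1-fold higher number from compound 3 to compound 4 (0.06 log units; within the scatter). The estimate for compound 4 is 150000 nM, with a range from 70000 nM to 320000 nM.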

Compound 4, half-maximal cytotoxic concentration: 83300 nM
Estimate against measurement, compound 4: 1.8-fold (0.26 log units) above, and the stated range covers the measured number.
By their numbers in this assay, from the lowest: compounds 4, 2, 3 and 1 (each within the scatter of the next, the first and the last beyond it).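

In this assay, fluoro in place of hydrogen on an aromatic carbon gives a 2.2-fold lower number from compound 1 to compound 4 (0.35 log units; beyond the scatter), so compound 4 joins compound 2 as a second case in which a single substituent on the phenyl group takes the number beyond the scatter of compound 1, while compound 3, with its two methyl groups, goes against this pattern by staying within that scatter. Among the substituted groups no separation appears: fluoro in place of methoxy on an aromatic carbon gives a 1.0-fold lower number from compound 2 to compound 4 (0.02 log units; within the scatter), and 4-fluorophenyl in place of 2,5-dimethylphenyl on a sulfonyl sulfur gives a 1.6-fold lower number from compound 3 to compound 4 (0.20 log units; within the scatter). Nothing available on these compounds accounts for the result.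

The compounds shown leave open whether an amine or a carboxylic acid on this aryl group would fall within the same scatter as compound 2, compound 3 and compound 4. They also leave open what a simple methyl group in place of the aryl group on the sulfonyl sulfur would do to the number.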